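Sulfonamide series: vinylphenyl for dichlorophenyl on compound 1

The source may report more compounds than this note shows. Statements on the series, on what has been measured and on what is new or still open speak of the compounds shown alone.

Measured so far:
compound 1, `O=S(=O)(Nc1ccc2oc(-c3ccccc3)nc2c1)c1ccc(Cl)c(Cl)c1`: > 63000 nM
compound 2, `O=S(=O)(Nc1ccc2oc(-c3ccccc3)nc2c1)c1ccc(Cl)c(C(F)(F)F)c1`: > 63000 nM
compound 3, `C=Cc1ccc(S(=O)(=O)Nc2ccc(-c3nc4ccccc4o3)cc2)cc1`: > 63000 nM

In an assay on isolated protein for inhibition of malate dehydrogenase, mitochondrial (Sus scrofa), with stated times of 45 min and 30 min (on this read-out lower numbers stand for stronger inhibition and higher numbers for weaker inhibition), compound 1 gives > 63000 nM, a limit of the assay and not a number. Compound 2 likewise gives only > 63000 nM, a limit. Compound 3 gives > 63000 nM, again a limit. Every value shown is a limit, as the limit of > 63000 nM in this assay, at which 3 of the 3 values shown sit, states, so compound 1 cannot be placed within the range of the assay. For the measured compounds named here, the one measured step, a step that the two limits leave unreadable from compound 1 to compound 2, is unreadable. Compound 4, `C=Cc1ccc(S(=O)(=O)Nc2ccc3oc(-c4ccccc4)nc3c2)cc1`, differs from compound 1 by 4-vinylphenyl in place of 3,4-dichlorophenyl on a sulfonyl sulfur. Compound 3 carries the same 4-vinylphenyl sulfonamide on a different arrangement of the shared core and sits at the limit. Going by the values given here, no measured step reads this change; the expected step is a step that the limit leaves unreadable from compound 1 to compound 4. Compound 4 is therefore estimated at 100000 nM, with a range of 30000 nM to 400000 nM, most probably again only a limit.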

Compound 4, half-maximal inhibitory concentration: > 63000 nM
Compound 4: only a limit was reported (the forecaster's own chance of this, stated with the estimate: 85%); the middle value does not contradict the limit.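

Compound 1 and compound 4 both give only a limit, so the step between them cannot be read: the limit of > 63000 nM in this assay, at which 4 of the 4 values shown sit.

The compounds shown leave open which structural change, if any, would give a readable number in this assay.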